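A Methyl Replaces Fluoro: Compound 4 Expected Near Compound 2

The compounds below may be only part of what the source reports. "The series", "measured", "known", "first", "only" and "open" are said of these compounds alone.

Three compounds were tested in a functional assay on CNE-2 cells (Homo sapiens) for cytotoxicity, read by MTT assay, with a stated time of 72 h; on this read-out higher numbers stand for weaker inhibition and lower numbers for stronger inhibition. Compound 1 `O=C(NC(=S)NNc1ncnc2ccccc12)c1ccc(C(F)(F)F)cc1` gives 22500 nM, compound 2 `COc1cc2ncnc(NNC(=S)NC(=O)c3ccc(F)cc3)c2cc1OC` gives 16100 nM, and compound 3 `COc1ccccc1C(=O)NC(=S)NNc1ncnc2ccccc12` gives 15700 nM. Compound 2 holds the second highest of the three numbers, yet its gap to compound 3 and its gap to compound 1 both fall within the scatter of repeated measurements, so no order among them can be read. Compound 4 `COc1cc2ncnc(NNC(=S)NC(=O)c3ccc(C)cc3)c2cc1OC` differs from compound 2 in one place: methyl in place of fluoro on an aromatic carbon. For the measured compounds named here, no measured pair shows this change, so the expected step is a 1.0-fold lower number from compound 2 to compound 4 (0.00 log units; within the scatter), small and not beyond the scatter in either direction. In this assay compound 4 is therefore expected to give 16000 nM, with a range from 8000 nM to 32000 nM.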

Compound 4, half-maximal inhibitory concentration: 33300 nM
The estimate for compound 4 lay 2.1-fold (0.32 log units) below the measured number, and the stated range ends below it.
By their numbers in this assay, from the lowest: compounds 3, 2, 1 and 4 (each within the scatter of the next, the first and the last beyond it).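

In this assay, for the compounds shown here, going from 4-fluorophenyl to 4-methylphenyl gives a 2.1-fold higher number from compound 2 to compound 4 (0.32 log units; beyond the scatter) and is the only step at hand that can be read, so this position para to a large group responds to the group it carries. The earlier compounds shown here held no pair differing in one place and could not show this. Nothing measured here accounts for the step. From the compounds shown here alone, whether an amine, a hydroxyl or a chloro group at this place would give a lower number stays open, as does whether the same change has a similar effect on the core of compound 1.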